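The source may hold more compounds than are shown below. What is called first, only, known or untested is meant among the compounds shown, and "the series" means these compounds.

Working notes on the series. The read-out throughout is a functional assay on HeLa cells (Homo sapiens) for inhibition, read by cell counting, with a stated time of 4 days; on this read-out higher numbers stand for weaker inhibition and lower numbers for stronger inhibition. Compound 1 `CCc1ccc(-c2nn3cc(-c4cccc(N)c4)nc3s2)cc1` gives 8100 nM in this assay. Compound 2 `C=C(Br)C(=O)Nc1cccc(-c2cn3nc(-c4ccccc4)sc3n2)c1` gives 1400 nM, and compound 3 `C=C(Br)C(=O)Nc1cccc(-c2cn3nc(-c4cccc(OC)c4)sc3n2)c1` gives 1100 nM. Compound 3 thus holds the lowest of the three numbers: compound 2 sits nearest, within the scatter, while compound 1 stands furthest away, beyond the scatter. Among the compounds with values here, only one single-place step has been measured, a 1.3-fold lower number from compound 2 to compound 3 (0.10 log units; within the scatter), an exchange on the pendant aryl ring that leaves the number essentially unchanged.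

Compound 4 `C=C(Br)C(=O)Nc1cccc(-c2cn3nc(-c4ccc(CC)cc4)sc3n2)c1` has not yet been measured. Relative to compound 3 the change is 4-ethylphenyl in place of 3-methoxyphenyl on an aromatic carbon. Within the data shown here, compound 1 also carries a 4-ethylphenyl, but it differs from compound 4 in more than one place, so its value and that of compound 3 can only be read as they stand, with no step drawn between them. Among the measured compounds shown here, the one relevant step, the aryl exchange between compound 2 and compound 3, was within the scatter, and an exchange of one aryl substituent pattern for another on the same ring is therefore expected to give a step of a 1.2-fold higher number from compound 3 to compound 4 (0.07 log units; within the scatter) that stays within the scatter, in no firm direction. Compound 4 is accordingly estimated at 1300 nM, with a range from 500 nM to 3500 nM.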

Compound 4, half-maximal inhibitory concentration: 3200 nM
Estimate against measurement, compound 4: 2.5-fold (0.39 log units) below; the measured number falls inside the stated range.
By their numbers in this assay, from the lowest: compounds 3 and 2 (each within the scatter of the next); then compound 4; then compound 1.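

Working notes, continued. In this assay, within the data shown here, the aryl group on the five-membered aromatic ring is no longer a silent position: a 2.9-fold higher number from compound 3 to compound 4 (0.46 log units; beyond the scatter) and a 2.3-fold higher number from compound 2 to compound 4 (0.36 log units; beyond the scatter) both lie beyond the scatter, though both are modest, whereas a 1.3-fold lower number from compound 2 to compound 3 (0.10 log units; within the scatter) stayed within it, so the 4-ethylphenyl pattern is the first change at this place to move the number. Among these compounds, the same compound also gives the first single-place reading of the other end of the series, where (1-bromoethenyl)carbonyl in place of hydrogen on the aromatic amine nitrogen, with 4-ethylphenyl held constant, gives a 2.5-fold lower number from compound 1 to compound 4 (0.40 log units; beyond the scatter), a modest step in the opposite direction. No measurement given here accounts for either shift.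

Open, going by these compounds, is how much of the rise at the aryl position follows the ethyl group itself, since a propyl chain, a hydroxyl group or an amine in its place would show whether the number keeps climbing or falls back. On the amide side, open is whether the lower number needs the bromine, which a plain acryloyl or an acetyl group on the same nitrogen would test.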